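Anilino Substituent Swap on a Shared Hydroxamate Core

A few compounds are considered here, and "the series" means these few. Any claim that something is new, unique, unknown or untested is made for them only; others in the source may bear on it.

Measured compounds:
Compound 1, `Cc1ccccc1Nc1ncnc2cc(NC(=O)CCCCCCC(=O)NO)sc12`: in an assay on cells for inhibition of protein deacetylase HDAC6 (Homo sapiens), with a stated time of 3 h (a higher number here means a weaker inhibitor, a lower number a stronger inhibitor), compound 1 gives 87.6 nM.
Compound 2, `Cc1cc(F)ccc1Nc1ncnc2cc(NC(=O)CCCCCCC(=O)NO)sc12`: in this assay compound 2 gives 120 nM.
Compound 3, `N#Cc1cccc(Nc2ncnc3cc(NC(=O)CCCCCCC(=O)NO)sc23)c1`: in this assay compound 3 gives 20.1 nM.

Compound 3 has the lowest number of the three. Its nearest neighbour is compound 1, the step of a 4.4-fold lower number from compound 1 to compound 3 (0.64 log units; beyond the scatter); further off is compound 2, the step of a 6.0-fold lower number from compound 2 to compound 3 (0.78 log units; beyond the scatter). The remaining step, a 1.4-fold higher number from compound 1 to compound 2 (0.14 log units; within the scatter), changes nothing outside the scatter.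

Compound 4, `COc1ccc(Nc2ncnc3cc(NC(=O)CCCCCCC(=O)NO)sc23)cc1`, is the next compound to be measured. It differs from compound 3 at the anilino substituent: 4-methoxyphenyl in place of 3-cyanophenyl on a nitrogen on an aromatic ring.

Among the measured compounds shown here, two measured steps bear on this change, since both replace the aryl group on the same nitrogen and both arrive at the 3-cyanophenyl of compound 3 with a modest lowering of the number. Leaving the 3-cyanophenyl for a different aryl group, as compound 4 does, is therefore expected to move in the opposite direction, with a step of comparable size, a 3.5-fold higher number from compound 3 to compound 4 (0.54 log units; beyond the scatter). For the measured compounds named here, no measured step shows a 4-methoxyphenyl directly, so the range is kept wide.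

Compound 4 is thus estimated at 70 nM in this assay, with a likely range from 30 nM to 160 nM.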

Compound 4, half-maximal inhibitory concentration: 71.4 nM
Beside the measured number, compound 4's estimate is 1.0-fold (0.01 log units) below it; the range from low to high includes it.
By their numbers in this assay, from the lowest: compound 3; then compounds 4, 1 and 2 (each within the scatter of the next).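

In this assay, the step to the 4-methoxyphenyl, a 3.6-fold higher number from compound 3 to compound 4 (0.55 log units; beyond the scatter), shows that the low number of compound 3 does not extend to every aryl group free of the methyl found in compounds 1 and 2, so among the four aryl groups on this nitrogen only the 3-cyanophenyl stands apart. Compound 4 cannot be separated from the two methyl-bearing compounds, since a 1.2-fold lower number from compound 1 to compound 4 (0.09 log units; within the scatter) and a 1.7-fold lower number from compound 2 to compound 4 (0.23 log units; within the scatter) both lie within the scatter, and the three aryl groups in compounds 1, 2 and 4 therefore read alike here despite their different substituents. Nothing among the data shown offers an explanation for why the 3-cyanophenyl stands apart.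

The compounds shown leave open whether the low number follows the nitrile itself or the place it holds on the ring, a question on which a 4-cyanophenyl or a 3-methoxyphenyl on the same nitrogen would bear. They also leave open how an unsubstituted phenyl, or a phenyl carrying an amine or a carboxylic acid, would compare with compound 3 in this assay.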